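This account rests on a few compounds, and the source may have more. Where it says the series, first, only, none or still open, it means among the compounds named here.

Working notes on the series. Three compounds have been run in a functional assay on A549 cells (Homo sapiens), read by MTT assay, with a stated time of 72 h; on this read-out lower numbers stand for stronger inhibition and higher numbers for weaker inhibition. Compound 1 `Nc1nc(N)c2c(-c3ccsc3)cn([C@@H]3O[C@H](CO)[C@@H](O)[C@H]3O)c2n1` carries two amino groups on the core and a thiophen-3-yl group; in this assay compound 1 returns only a limit, > 100000 nM. Compound 2 `O=c1[nH]cnc2c1c(-c1cc3ccccc3o1)cn2[C@@H]1O[C@H](CO)[C@@H](O)[C@H]1O` bears 1-benzofuran-2-yl on the same aromatic carbon and likewise gives only a limit in this assay, > 20000 nM. Compound 3 `O=c1[nH]cnc2c1c(-c1cccs1)cn2[C@@H]1O[C@H](CO)[C@@H](O)[C@H]1O` carries thiophen-2-yl there, and in this assay compound 3 also stops at a limit, > 20000 nM. Compound 3 therefore stands at a limit, and the two further values shown are limits as well, one at the limit of > 100000 nM in this assay, at which 1 of the 3 values shown sits, and two at the limit of > 20000 nM in this assay, at which 2 of the 3 values shown sit. Among the measured compounds shown here, the single one-place step, a step that the two limits leave unreadable from compound 2 to compound 3, cannot be read, since both ends sit at limits.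

Compound 4 `O=c1[nH]cnc2c1c(-c1ccccc1)cn2[C@@H]1O[C@H](CO)[C@@H](O)[C@H]1O` differs from compound 3 by phenyl in place of thiophen-2-yl on an aromatic carbon. No measured step is readable for this change, so nothing among the shown values points to a direction for it. Compound 4 is expected to sit near the limits of the series, estimated at 30000 nM with a range of 8000 nM to 100000 nM. The step that the limit leaves unreadable from compound 3 to compound 4 is thus expected to stay within the scatter, with a limit rather than a number the most likely outcome.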

Compound 4, half-maximal inhibitory concentration: > 100000 nM
Compound 4: no number, only a limit (the forecaster's own chance of this, stated with the estimate: 70%); middle value at least 3.3-fold (0.52 log units) away from the limit.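

In this assay compound 4 also returns only a limit, > 100000 nM. Compound 2, compound 3 and compound 4 all stop at limits, so the steps among them cannot be read. The compounds shown leave open whether thiophen-2-yl, phenyl or 1-benzofuran-2-yl on this aromatic carbon gives a measurable value in this assay, and how these groups rank.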